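This account rests on a few compounds, and the source may have more. Where it says the series, first, only, none or still open, it means among the compounds named here.

Compound 1 `O=C(NCc1ccc(OCc2ccccc2)cc1)n1cccn1` carries the same benzyloxy-benzyl piece and a carbonyl attached to a five-membered nitrogen ring, but in an assay on membranes from brain for binding affinity to Monoacylglycerol lipase ABHD6 (Mus musculus), read by fluorescence, with stated times of 1 h and 30 min (a lower number here means a stronger inhibitor, a higher number a weaker inhibitor), compound 1 gives "not determined" (no result reported), so it offers no number to compare. Within the data shown here, compound 2 `Cc1cnn(C(=O)N(C)CCN(C)Cc2ccc(OCc3ccccc3)cc2)c1` is therefore the only compound here with a number: in this assay compound 2 gives 1200 nM, which makes it the sole reference point rather than a strong or weak member of a series. Compound 3 `CN(CCN(C)C(=O)n1cc(C#N)cn1)Cc1ccc(OCc2ccccc2)cc1` has not yet been tested. It differs from compound 2 in one place only: cyano in place of methyl on an aromatic carbon, so the methyl on the five-membered ring is swapped for a nitrile. Among the measured compounds shown here, no pair of measured compounds shows what this swap does here, so the size and direction of its effect have to be guessed. The expectation is a moderate gain in potency, with a real chance that the change stays within the scatter; the step from compound 2 to compound 3 is expected to be a 2.7-fold lower number from compound 2 to compound 3 (0.43 log units; beyond the scatter). In this assay compound 3 is estimated at 450 nM, within a range from 120 nM to 1800 nM.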

Compound 3, half-maximal inhibitory concentration: 320 nM
The estimate for compound 3 lay 1.4-fold (0.15 log units) above the measured number; low and high end bracket the measured number.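

In this assay, replacing 4-methyl-1H-pyrazol-1-yl with 4-cyano-1H-pyrazol-1-yl gives a 3.8-fold lower number from compound 2 to compound 3 (0.57 log units; beyond the scatter), so the group on this aromatic carbon of the five-membered ring matters: changing it alone, with the rest of the structure held the same, moves the number beyond the usual scatter of repeated measurements. Among these compounds, until now no such statement was possible, as compound 2 offered a lone number and compound 1 gave "not determined" (no result reported); this is the first measured step in the set, and it runs towards a stronger inhibitor with the nitrile in place of the methyl. No measurement shown here explains the step, so the reason for it remains unknown.

A single step cannot show whether the nitrile is unusual at this position or whether other groups, such as a chlorine atom, an amide or a carboxylic acid, would do as well or better. It also leaves open whether the swap would give a step of similar size if the benzyloxy piece or the chain joining it to the carbonyl were changed.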